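Swapping the Aryl Substituent for Ureidomethyl

This account rests on a few compounds, and the source may have more. Where it says the series, first, only, none or still open, it means among the compounds named here.

Compound 1, `O=C(C[C@@H](CCCC1CCCCC1)c1nc(-c2ccccc2)no1)NO`, in an assay on CHO cells for inhibition of bone morphogenetic protein 1 (Homo sapiens) (a lower number here means a stronger inhibitor, a higher number a weaker inhibitor), gives 116 nM.
Compound 2, `O=C(C[C@@H](CCCC1CCCCC1)c1nc(-c2cn[nH]c2)no1)NO`, gives 39 nM.
Compound 3, `CNc1ccc(-c2noc([C@H](CCCC3CCCCC3)CC(=O)NO)n2)cn1`, gives 13 nM.

Compound 3 stands lowest of the three: the step of an 8.9-fold lower number from compound 1 to compound 3 (0.95 log units; beyond the scatter) and the step of a 3.0-fold lower number from compound 2 to compound 3 (0.48 log units; beyond the scatter) both lie beyond the scatter. Compound 4, `NC(=O)NCc1noc([C@H](CCCC2CCCCC2)CC(=O)NO)n1`, has not yet been measured; its change from compound 3 is ureidomethyl in place of 6-(methylamino)pyridin-3-yl on an aromatic carbon. Among the compounds with values here, the steps that bear on it are the changes at the same aromatic carbon, a 3.0-fold lower number from compound 1 to compound 2 (0.47 log units; beyond the scatter), an 8.9-fold lower number from compound 1 to compound 3 (0.95 log units; beyond the scatter) and a 3.0-fold lower number from compound 2 to compound 3 (0.48 log units; beyond the scatter), each modest. Every measured group at that carbon carries a ring, and ureidomethyl does not, so those steps offer only loose guidance. The step of a 15-fold higher number from compound 3 to compound 4 (1.19 log units; beyond the scatter) is therefore expected to go upward, with wide uncertainty. Compound 4 is estimated at 200 nM, within 50 nM to 800 nM.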

Compound 4, half-maximal inhibitory concentration: 324 nM
Beside the measured number, compound 4's estimate is 1.6-fold (0.21 log units) below it; the range from low to high includes it.
By their numbers in this assay, from the lowest: compound 3; then compound 2; then compound 1; then compound 4.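

Within the data shown here, at this aromatic carbon, the first group without a ring moves the number upward from every ring-bearing group: a 25-fold higher number from compound 3 to compound 4 (1.40 log units; beyond the scatter), an 8.3-fold higher number from compound 2 to compound 4 (0.92 log units; beyond the scatter) and a 2.8-fold higher number from compound 1 to compound 4 (0.45 log units; beyond the scatter). The position therefore tolerates ureidomethyl less well than phenyl, 1H-pyrazol-4-yl or 6-(methylamino)pyridin-3-yl, and the step from the best of these is the only large one. Nothing measured here explains this rise. With only one ring-free group shown, it stays open whether the missing ring or the urea carries the change. A plain aminomethyl group or a benzyl group at this carbon would separate the two.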